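Changing the Six-Membered Ring on the Core and Solubility

The source may hold more compounds than are shown below. What is called first, only, known or untested is meant among the compounds shown, and "the series" means these compounds.

Compound 1 `CN(C)C(=O)CN1CCC(c2cc3c(-c4ccc(=O)n(C5CCC5)c4)ccnc3[nH]2)CC1`: > 1000000 nM
Compound 2 `CC(C)n1nc(-c2ccnc3[nH]c(C4CCN(CC(=O)N(C)C)CC4)cc23)ccc1=O`: 11000 nM
Compound 3 `CC(C)n1cc(-c2ccnc3[nH]c(C4CCN(CC(=O)N5CCCCC5)CC4)cc23)ccc1=O`: 79000 nM

Of the compounds shown here, three sharing one core have been measured in a physicochemical assay for solubility, in phosphate buffer, at pH 7.4; a lower number here means a less soluble compound, a higher number a more soluble compound. For compound 1 the value is a limit of the assay, not a number (the limit of > 1000000 nM in this assay, at which 1 of the 3 values shown sits). Among the two real numbers, compound 2 stands lowest, and compound 3 sits higher by a gap beyond the usual scatter.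

Compound 4 `COc1cc(=O)n(C)cc1-c1ccnc2[nH]c(C3CCN(CC(=O)N(C)C)CC3)cc12` has not yet been measured. It differs from compound 2 at one place (a group of 10 heavy atoms (7 carbon, 1 nitrogen, 2 oxygen; one six-membered aromatic ring with 1 hetero atom) in place of a group of 10 heavy atoms (7 carbon, 2 nitrogen, 1 oxygen; one six-membered aromatic ring with 2 hetero atoms), on an aromatic carbon). For the measured compounds named here, no measured pair shows this exact exchange. Going by the values given here, the step from compound 2 to compound 4 therefore has no direct precedent. Since compound 2 sits at 11000 nM, the lowest number shown, the expectation is an upward step in this assay, beyond the scatter. This step is estimated as a 9.1-fold higher number from compound 2 to compound 4 (0.96 log units; beyond the scatter). Compound 4 is therefore expected to give about 100000 nM, with a likely range from 20000 nM to 600000 nM.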

Compound 4, solubility: 670000 nM
Compound 4: the middle estimate sits 6.7-fold (0.83 log units) below what was measured; the whole stated range lies below it.
By their numbers in this assay, from the lowest: compound 2; then compound 3; then compound 4. At a limit, above all of these: compound 1.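

In this assay, for the compounds shown here, exchanging the group on this aromatic carbon, opposite the ring nitrogen, gives a 61-fold higher number from compound 2 to compound 4 (1.78 log units; beyond the scatter), the first step in this set that can be read at a single place. The group that leaves and the group that enters have the same counts of heavy atoms, hydrogen-bond donors and acceptors, and neither carries a net charge, yet the step is large. Compound 1, which carries a third group at this same place, gives a limit of the assay and not a number: the limit of > 1000000 nM in this assay, at which 1 of the 4 values shown sits.

The exchange removes a ring nitrogen and changes the ring's substituents all at once, so the compounds shown cannot tell which of these changes matters. Going by these compounds, how an amine or a carboxylic acid on this ring would read also stays open.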